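Shortening the Chain on the Ring Nitrogen

A few compounds are considered here, and "the series" means these few. Any claim that something is new, unique, unknown or untested is made for them only; others in the source may bear on it.

Two compounds share a core in which a ring nitrogen carries a straight chain. Compound 1 `CCCCN1C(=O)NC(=O)/C1=C\c1ccccc1` carries a butyl chain, compound 2 `CCCCCCN1C(=O)NC(=O)/C1=C\c1ccccc1` a hexyl chain. In a functional assay on A549 cells (Homo sapiens) for antiproliferative activity, read by trypan blue exclusion, with a stated time of 72 h, tested at 20 uM (a higher number here means more inhibition at the concentration tested (going by the name of the read-out), a lower number less inhibition), compound 2 gives 14%, and compound 1 gives 6.8%. Compound 2 holds the larger of the two numbers recorded, but the gap to compound 1 lies within the scatter: a number 7.2 percentage points higher from compound 1 to compound 2 (within the scatter) came with ethyl in place of hydrogen on a saturated chain carbon, four bonds along the chain from an amide-type nitrogen in a ring.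

Compound 3 `CN1C(=O)NC(=O)/C1=C\c1ccccc1` differs from compound 2 by hydrogen in place of pentyl on a saturated chain carbon bound to an amide-type nitrogen in a ring. Within the data shown here, the single step that bears on this change, a number 7.2 percentage points higher from compound 1 to compound 2 (within the scatter), was small. Lengthening the chain barely moved the number, so shortening it is expected to leave the number near where it is. For compound 3 the expected value is 6%, within a range from 0% to 18%. That expectation amounts to an estimated step of a number 8 percentage points lower from compound 2 to compound 3 (within the scatter).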

Compound 3, a percentage reported as inhibition, at one concentration (the size of the read-out at that concentration, not a potency): 5.7%
Compound 3: middle estimate off by 0.3 percentage points, on the high side; measured number inside the range.
By their numbers in this assay, from the lowest: compounds 3, 1 and 2 (each within the scatter of the next).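

With methyl on the ring nitrogen, the chains now run from hexyl through butyl to methyl, and this assay does not tell them apart: the hexyl to methyl change gives a number 8.3 percentage points lower from compound 2 to compound 3 (within the scatter) and the butyl to methyl change gives a number 1.1 percentage points lower from compound 1 to compound 3 (within the scatter) in the same test. Even the loss of pentyl, the largest change at this position among these compounds, therefore stays within the scatter, so no link between chain length and the number can be read from the three. No separate measurement is available to explain why these numbers sit so close together.

Going by these compounds, whether a longer chain such as decyl would give a number beyond the scatter remains open. So does the effect of a chain ending in an amine or a carboxylic acid, or of a benzyl group on the same nitrogen.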